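Ethoxycarbonyl in place of acetyl(methyl)amino on compound 1

This account rests on a few compounds, and the source may have more. Where it says the series, first, only, none or still open, it means among the compounds named here.

Compound 1 `CC(=O)N(C)c1ccc(Nc2nccc(-c3cccnc3)n2)cc1` gives 900 nM in a functional assay for inhibition, with Homo sapiens as the target; on this read-out lower numbers stand for stronger inhibition and higher numbers for weaker inhibition. Among the three numbers measured so far it stands second highest: compound 2 `c1ccc(-c2ccnc(Nc3ccc(-n4ccnc4)cc3)n2)nc1` gives 1400 nM, a gap within the scatter, and compound 3 `CC(=O)N(C)c1ccc(Nc2nccc(-c3ccncc3)n2)cc1` gives 500 nM, with the step of a 1.8-fold lower number from compound 1 to compound 3 (0.26 log units; within the scatter) also within the scatter. Compound 4 `CCOC(=O)c1ccc(Nc2nccc(-c3cccnc3)n2)cc1` differs from compound 1 in one place: ethoxycarbonyl in place of acetyl(methyl)amino on an aromatic carbon. For the measured compounds named here, no measured step touches this position; the only step on record, a 1.8-fold lower number from compound 1 to compound 3 (0.26 log units; within the scatter), concerns another position and stayed within the scatter. With nothing bearing on the exchange, a number near compound 1 is expected for compound 4, with a wide range. The expected step is no change at the digits printed from compound 1 to compound 4 (within the scatter). The estimate for compound 4 is 900 nM, between 300 nM and 2700 nM.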

Compound 4, half-maximal inhibitory concentration: 12400 nM
Estimate against measurement, compound 4: 14-fold (1.14 log units) below, and the stated range ends below it.
By their numbers in this assay, from the lowest: compounds 3, 1 and 2 (each within the scatter of the next, the first and the last beyond it); then compound 4.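

For the compounds shown here, at the aromatic carbon para to a large group, the series is sensitive to the choice of group in this assay: ethoxycarbonyl in place of acetyl(methyl)amino gives a 14-fold higher number from compound 1 to compound 4 (1.14 log units; beyond the scatter), the only step on record beyond the scatter. The two groups have the same heavy-atom count, and neither has a ring or a hydrogen-bond donor, so these counts do not settle the outcome at this position. Nothing on record accounts for the step.

Open, going by these compounds, is whether other groups at this position, such as a carboxylic acid, a primary amide or an amine, stay near compound 1 or near compound 4. Also open, on these data alone, is how pyridin-4-yl in place of pyridin-3-yl reads with ethoxycarbonyl on the core.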